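This account rests on a few compounds, and the source may have more. Where it says the series, first, only, none or still open, it means among the compounds named here.

Two compounds of the series have numbers in an ADME assay on MT4 cells (Homo sapiens) for cytotoxicity, read by MTT assay, with a stated time of 5 days; a lower number here means that less compound is tolerated, a higher number that more compound is tolerated. Compound 1 `N#Cc1ccc(Nc2nccc(Oc3ccc(C(=O)c4ccc(O)cc4)cc3)n2)cc1` gives 19400 nM in this assay, the lowest of the two numbers. Compound 2 `COCCc1ccc(Oc2ccnc(Nc3ccc(C#N)cc3)n2)cc1` gives 93300 nM in this assay. For the measured compounds named here, the one measured step, a 4.8-fold higher number from compound 1 to compound 2 (0.68 log units; beyond the scatter), is 2-methoxyethyl in place of (4-hydroxyphenyl)carbonyl on an aromatic carbon. Compound 3 `Cc1cnc(Nc2ccc(C#N)cc2)nc1Oc1ccc(C(=O)c2ccc(O)cc2)cc1` has not yet been measured. It differs from compound 1 by methyl in place of hydrogen on an aromatic carbon of the core, ortho to a large group, two atoms from the ring nitrogen and para to the (4-cyanophenyl)amino group. Going by the values given here, no measured step touches this position; the step from compound 1 to compound 2 changes a different part of the molecule and gives no direct guide. For compound 3 the step of a 1.0-fold lower number from compound 1 to compound 3 (0.01 log units; within the scatter) is expected to stay within the scatter. Compound 3 is therefore estimated at 19000 nM in this assay, within 7000 nM to 55000 nM.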

Compound 3, half-maximal cytotoxic concentration: > 295000 nM
Compound 3 gave a limit, no number (the forecaster's own chance of this, stated with the estimate: 10%); middle value at least 15-fold (1.19 log units) away from the limit.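

In this assay compound 3 stands at a limit of the assay, not at a number: the limit of > 295000 nM in this assay, at which 1 of the 3 values shown sits. Methyl in place of hydrogen on this aromatic carbon of the core, ortho to a large group, gives an at least 15-fold higher number from compound 1 to compound 3 (1.18 log units; beyond the scatter), so a single added carbon at this position is enough for a large step, whereas the exchange of the whole (4-hydroxyphenyl)carbonyl group gave only a modest one, a 4.8-fold higher number from compound 1 to compound 2 (0.68 log units; beyond the scatter). Compound 3 keeps the (4-hydroxyphenyl)carbonyl group, so that group alone does not set the number in this series.

The true value of compound 3 cannot be read from a limit, and one substituent at one position gives no trend. Going by these compounds, whether ethyl, methoxy or an amine on the same carbon follows methyl stays open, as does whether methyl there gives a similar step alongside 2-methoxyethyl.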